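The source may report more compounds than this note shows. Statements on the series, on what has been measured and on what is new or still open speak of the compounds shown alone.

Measured so far:
- Compound 1 `O=C(O)CC/C=C\CC1COC(c2ccccc2Cl)OC1c1cccnc1`: 48 nM
- Compound 2 `N#Cc1ccc(C2OCC(C/C=C\CCC(=O)O)C(c3cccnc3)O2)cc1`: 24 nM

In an assay for inhibition of Thromboxane-A synthase (Homo sapiens), using microsomes (on this read-out higher numbers stand for weaker inhibition and lower numbers for stronger inhibition), compound 2 gives 24 nM, the lowest of the two numbers. Among the measured compounds shown here, compound 1 gives 48 nM in this assay, and the single measured step, a 2.0-fold lower number from compound 1 to compound 2 (0.30 log units; within the scatter), lies within the usual scatter, so the two compounds cannot be told apart on these data.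

Compound 3 `N#Cc1ccccc1C1OCC(C/C=C\CCC(=O)O)C(c2cccnc2)O1` is the next compound to be tested. It differs from compound 2 in one place: 2-cyanophenyl in place of 4-cyanophenyl on a saturated ring carbon. For the measured compounds named here, only one measured step exists, and it changed both the group and where it sits on the phenyl ring, so it bears on this change only loosely. Because that step was a 2.0-fold lower number from compound 1 to compound 2 (0.30 log units; within the scatter), no step beyond the scatter is expected here.

Compound 3 is therefore expected to give 35 nM in this assay, with a range from 12 nM to 100 nM. This estimate means a step of a 1.5-fold higher number from compound 2 to compound 3 (0.16 log units; within the scatter).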

Compound 3, half-maximal inhibitory concentration: 54 nM
The estimate for compound 3 lay 1.5-fold (0.19 log units) below the measured number; the range from low to high includes it.
By their numbers in this assay, from the lowest: compounds 2, 1 and 3 (each within the scatter of the next, the first and the last beyond it).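

Among the compounds shown here, putting 2-cyanophenyl in place of 4-cyanophenyl on the saturated ring carbon between two ring oxygen atoms gives the first step here that clears the scatter, though only modestly, in this assay (a 2.3-fold higher number from compound 2 to compound 3 (0.35 log units; beyond the scatter)). This shows that where the nitrile sits on the phenyl ring can shift the number even with the same atoms, whereas exchanging the group on the aromatic carbon, cyano in place of chloro, leaves the two compounds indistinguishable (a 1.1-fold higher number from compound 1 to compound 3 (0.05 log units; within the scatter)). Nothing available explains why the nitrile's place on the ring makes this difference.

Still open, from the compounds shown here alone, is how 3-cyanophenyl would compare with these two isomers. Going by these compounds, it is also open whether 4-chlorophenyl would repeat the same difference, or whether it belongs to the nitrile alone.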